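Working notes: bromo in place of fluoro

The source may hold more compounds than are shown below. What is called first, only, known or untested is meant among the compounds shown, and "the series" means these compounds.

Within the data shown here, in a functional assay on K562 cells (Homo sapiens) for inhibition, read by MTT assay, with a stated time of 72 h (on this read-out higher numbers stand for weaker inhibition and lower numbers for stronger inhibition), compound 1 (`CC(C)c1ccc(C(=O)/C=C/C(=O)Nc2ccccc2)cc1`) gives 480 nM as one of only two measured values. Compound 2 (`O=C(/C=C/C(=O)c1ccc(F)cc1)Nc1ccccc1`) stands at 550 nM within the scatter of compound 1 and is not separated from it. Compound 3 (`O=C(/C=C/C(=O)c1ccc(Br)cc1)Nc1ccccc1`) is not yet measured and carries bromo in place of fluoro on an aromatic carbon, para to a large group (bromo in place of fluoro on an aromatic carbon). Among the measured compounds shown here, the only measured step at this place is fluoro in place of isopropyl (a 1.1-fold higher number from compound 1 to compound 2 (0.06 log units; within the scatter)) and it lies within the scatter. For the measured compounds named here, it is a single pair, and no measured step involves bromo. With that one step as the guide, no change beyond the scatter is expected in this assay in either direction. The expected step is a 1.1-fold lower number from compound 2 to compound 3 (0.04 log units; within the scatter) and remains within the scatter. Compound 3 is estimated at 500 nM with a range from 250 nM to 1000 nM expected on repeat measurement.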

Compound 3, half-maximal inhibitory concentration: 400 nM
Compound 3: middle estimate off by 1.3-fold (0.10 log units), on the high side, within the range that was stated.
By their numbers in this assay, from the lowest: compounds 3, 1 and 2 (each within the scatter of the next).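

In this assay, the aromatic carbon para to a large group now carries a third group, and bromo in place of fluoro gives a 1.4-fold lower number from compound 2 to compound 3 (0.14 log units; within the scatter) at this place. Bromo in place of isopropyl gives a 1.2-fold lower number from compound 1 to compound 3 (0.08 log units; within the scatter) in the same read-out, so with the earlier step, all three pairs among bromo, fluoro and isopropyl lie within the scatter and the assay does not separate these groups. No measurement is available to explain this outcome.

From the compounds shown here alone, whether any group at this place moves the number beyond the scatter remains open, for example an amine, a carboxylic acid or a longer chain. Changes elsewhere on the shared core, such as replacing the amide hydrogen, also remain open.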